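The source may hold more compounds than are shown below. What is called first, only, known or untested is meant among the compounds shown, and "the series" means these compounds.

Three compounds sharing one core have so far been measured in a functional assay on WI-38 VA13 cells (Homo sapiens) for cytotoxicity; on this read-out higher numbers stand for an effect only at larger amounts of compound and lower numbers for an effect already at smaller amounts:

compound 1 `O=C(Nc1ccc2nc(NC(=O)C3CC3)sc2c1)c1c(Cl)cccc1Cl` gives 0.013 ug/mL
compound 2 `CCOC(=O)Nc1nc2ccc(NC(=O)c3c(Cl)cccc3Cl)cc2s1` gives 0.0026 ug/mL
compound 3 `CC(C)COC(=O)Nc1nc2ccc(NC(=O)c3c(Cl)cccc3Cl)cc2s1` gives 0.0035 ug/mL

Compound 3 belongs with the lower pair of numbers. Its closest neighbour lies within the scatter (a 1.3-fold higher number from compound 2 to compound 3 (0.13 log units; within the scatter)), while the remaining value stands clearly apart (a 3.7-fold lower number from compound 1 to compound 3 (0.57 log units; beyond the scatter)).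

Compound 4 `CC(C)(C)OC(=O)Nc1nc2ccc(NC(=O)c3c(Cl)cccc3Cl)cc2s1`, not yet measured, differs from compound 3 in one group (tert-butyl in place of isobutyl on an oxygen next to a carbonyl group): tert-butyl in place of isobutyl on an oxygen next to a carbonyl group, so that isobutoxycarbonyl becomes tert-butoxycarbonyl. For the measured compounds named here, the closest precedent is the earlier exchange on the chain at that same oxygen, which stayed within the scatter (a 1.3-fold higher number from compound 2 to compound 3 (0.13 log units; within the scatter)). The two larger steps (a 5.0-fold lower number from compound 1 to compound 2 (0.70 log units; beyond the scatter) and a 3.7-fold lower number from compound 1 to compound 3 (0.57 log units; beyond the scatter)) put ethoxy or isobutoxy in place of cyclopropyl on a carbonyl carbon, a change compound 4 does not make. Going by the values given here, no measured compound carries tert-butyl, so the precedent is thin. A step beyond the scatter is therefore not expected in this assay, in either direction. The estimated step is small (no change at the digits printed from compound 3 to compound 4 (within the scatter)). For compound 4 the expected value is 0.0035 ug/mL (estimated range 0.0014 ug/mL to 0.009 ug/mL).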

Compound 4, half-maximal effective concentration: 0.027 ug/mL
The estimate for compound 4 lay 7.7-fold (0.89 log units) below the measured number, outside the stated range (above it).
By their numbers in this assay, from the lowest: compounds 2 and 3 (each within the scatter of the next); then compound 1; then compound 4.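

In this assay, the group on an oxygen next to a carbonyl group turns out not to be freely exchangeable. Tert-butyl in place of isobutyl, two groups with the same atoms joined differently, gives a 7.7-fold higher number from compound 3 to compound 4 (0.89 log units; beyond the scatter), and tert-butyl in place of ethyl gives a 10-fold higher number from compound 2 to compound 4 (1.02 log units; beyond the scatter), although the change from ethyl to isobutyl had stayed within the scatter. The lower numbers seen when ethoxy or isobutoxy replaced cyclopropyl on a carbonyl carbon also do not extend to every such group, since tert-butoxy in that place goes the other way, with a 2.1-fold higher number from compound 1 to compound 4 (0.32 log units; beyond the scatter), and compound 2 and compound 3 stand against compound 4 on this point; no measurement at hand bears on what lies behind this shift.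

For the compounds shown here, with tert-butyl the only group on that oxygen to show the higher number, it remains open whether isopropyl or cyclobutyl there would fall with compound 2 and compound 3 or with compound 4. Going by these compounds, it also remains open whether tert-butyl bound directly to the carbonyl carbon, without the oxygen, would give a number close to that of compound 1 or of compound 4.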